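Para Hydroxyl Replaces Meta Methoxy on a Biphenyl Pyrazole

The source may report more compounds than this note shows. Statements on the series, on what has been measured and on what is new or still open speak of the compounds shown alone.

Going by the values given here, compound 2 `COc1cccc(-c2cc(-c3ccccc3-c3ccccc3)n[nH]2)c1` stands at the weak end of the two numbers measured so far: in a functional assay on AGS cells (Homo sapiens) for inhibition, read by MTT assay, with a stated time of 48 h (on this read-out lower numbers stand for stronger inhibition of growth and higher numbers for weaker inhibition of growth), compound 2 gives 7500 nM, the higher of the pair. Its neighbour, compound 1 `COc1ccc(-c2cc(-c3ccccc3-c3ccccc3)n[nH]2)cc1`, gives in this assay a reading of 790 nM. Among the compounds with values here, the one measured step, a 9.5-fold higher number from compound 1 to compound 2 (0.98 log units; beyond the scatter), shows that moving the methoxy group from the 4-position to the 3-position of the pendant phenyl ring costs potency well beyond the scatter.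

Compound 3 `Oc1ccc(-c2cc(-c3ccccc3-c3ccccc3)n[nH]2)cc1` now differs from compound 2 as follows: 4-hydroxyphenyl in place of 3-methoxyphenyl on an aromatic carbon. Within the data shown here, this change returns the substituent to the 4-position, the arrangement that in compound 1 gave 790 nM, while also exchanging methoxy for hydroxyl, a swap for which no measured step exists here. The step from compound 1 to compound 2 bears on it in the opposite direction, so the author expects a return toward lower numbers in this assay, though the hydroxyl for methoxy exchange adds uncertainty. For compound 3 the expected step is a 5.0-fold lower number from compound 2 to compound 3 (0.70 log units; beyond the scatter). Compound 3 is estimated at 1500 nM, within a range of 400 nM to 6000 nM.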

Compound 3, concentration for 50% growth inhibition: 9200 nM
The estimate for compound 3 lay 6.1-fold (0.79 log units) below the measured number, outside the stated range (above it).
By their numbers in this assay, from the lowest: compound 1; then compounds 2 and 3 (each within the scatter of the next).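

In this assay, the methyl on the oxygen of compound 1 turns out to matter as much as the place of the group: hydrogen in its place gives a 12-fold higher number from compound 1 to compound 3 (1.07 log units; beyond the scatter), a large loss that the earlier pair could not reveal. Keeping the substituent at the 4-position is therefore not enough on its own, and the step of a 1.2-fold higher number from compound 2 to compound 3 (0.09 log units; within the scatter) leaves 4-hydroxyphenyl and 3-methoxyphenyl indistinguishable here, so that among the three groups shown on this aromatic carbon only the 4-methoxyphenyl of compound 1 stands apart. Nothing available here explains why the hydroxyl and the moved methoxy read alike or why either differs from compound 1.

The compounds shown leave open whether an amine, or a longer chain such as ethoxy, in place of the methoxy of compound 1 would read like compound 1 or like compounds 2 and 3. They also leave open whether the same order of the three compounds would hold on any cell line other than the one used here.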